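Ring-substituted coumarins at the adenosine receptor: notes

The source may hold more compounds than are shown below. What is called first, only, known or untested is meant among the compounds shown, and "the series" means these compounds.

Measured so far, as the inhibition constant in an assay on CHO cells for displacement of a labelled ligand from adenosine receptor A3 (Homo sapiens), read by radioligand binding; a lower number here means a stronger inhibitor, a higher number a weaker inhibitor:
- compound 1 `CCOc1cccc2cc(-c3ccccc3)c(=O)oc12` gives 22500 nM
- compound 2 `CCOc1cccc2cc(-c3ccc(OC)cc3)c(=O)oc12` gives 5320 nM
- compound 3 `CCOc1cccc2cc(-c3ccc(OC)c(OC)c3)c(=O)oc12` gives 13700 nM

Compound 2 holds the lowest number of the three in this assay; compound 3 sits nearest with a higher number, compound 1 furthest. The two measured steps are of the same kind, a methoxy in place of hydrogen on an aromatic carbon, and they pull in opposite directions: a 4.2-fold lower number from compound 1 to compound 2 (0.63 log units; beyond the scatter), whereas a 2.6-fold higher number from compound 2 to compound 3 (0.41 log units; beyond the scatter).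

Compound 4 `CCOc1cccc2cc(-c3ccc(OC)cc3OC)c(=O)oc12` is not yet measured. It differs from compound 2 by methoxy in place of hydrogen on an aromatic carbon. Going by the values given here, the step that bears on it most directly is the one from compound 2 to compound 3, since both add a further methoxy to a ring that already carries one; that step was a modest rise beyond the scatter. The step from compound 1 to compound 2 adds the first methoxy to an unsubstituted ring and is less comparable. A modest rise, in the direction of weaker binding, is therefore the expectation, with the size kept uncertain because the place differs from that of compound 3.

Compound 4 is expected to give 10000 nM in this assay, within 4000 nM to 30000 nM. That estimate means a step of a 1.9-fold higher number from compound 2 to compound 4 (0.27 log units; within the scatter), which is expected to fall just beyond the scatter.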

Compound 4, inhibition constant: 16600 nM
For compound 4 the middle estimate is 1.7-fold (0.22 log units) below the measured one, within the range that was stated.
By their numbers in this assay, from the lowest: compound 2; then compounds 3, 4 and 1 (each within the scatter of the next).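

In this assay the added methoxy, ortho to a large group and meta to a methoxy group, gives a 3.1-fold higher number from compound 2 to compound 4 (0.49 log units; beyond the scatter) and so a second methoxy raises the number at this place too, as it did in a 2.6-fold higher number from compound 2 to compound 3 (0.41 log units; beyond the scatter) on the way to the other two-methoxy compound. Compound 3 at 13700 nM and compound 4 at 16600 nM lie within the scatter of each other, so the two places that have been tried for the second methoxy cannot be told apart in this assay. The data shown hold no independent measurement that would account for the rise at this place.

Whether the rise belongs to methoxy itself or to any group at this place stays open, since a hydroxyl, an amine, a carboxylic acid or a longer alkoxy chain ortho to a large group does not appear among these compounds. Also open, on these data alone, is what a methoxy at this place would do on its own, with no methoxy meta to it, so the share of the existing methoxy in this step cannot be separated.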